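The compounds below may be only part of what the source reports. "The series", "measured", "known", "first", "only" and "open" are said of these compounds alone.

Compound 1 `COc1cc2nc(N3CCC(N4CCCC4)CC3)nc(NCc3ccccc3)c2cc1OC`: 10%
Compound 2 `COc1cc2nc(N3CCC(Cc4ccccc4)CC3)nc(NC3CCCCCC3)c2cc1OC`: 1%

Both compounds were tested in an in vitro functional assay on B300-19 cells for antagonist activity at C-C chemokine receptor type 4 (Homo sapiens), read by GTPgammaS binding, tested at 1 uM; a higher number here means more inhibition at the concentration tested (going by the name of the read-out), a lower number less inhibition. Compound 1 gives 10%, and compound 2 gives 1%; the two numbers lie within the usual scatter of each other, so neither stands apart. Compound 3 `COc1cc2nc(N3CCC(N4CCCC4)CC3)nc(N(C)C)c2cc1OC` has not yet been measured. It differs from compound 1 in one place: dimethylamino in place of benzylamino on an aromatic carbon. Going by the values given here, no step between measured compounds is known here, so the expectation rests only on the low readings of compound 1 and compound 2. The expected step is a number 5 percentage points lower from compound 1 to compound 3 (within the scatter), that is, none beyond the scatter. Compound 3 is estimated at 5%, between -10% and 20%.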

Compound 3, a percentage reported as inhibition, at one concentration (the size of the read-out at that concentration, not a potency): < 0%
Compound 3 was reported as a limit (the forecaster's own chance of this, stated with the estimate: 2%); middle value at least 5 percentage points away from the limit.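

In this assay compound 3 gives < 0%, a limit of the assay and not a number: the limit of < 0% in this assay, at which 1 of the 3 values shown sits. Putting dimethylamino in place of benzylamino removes the six-membered aromatic ring and the hydrogen-bond donor, and the step is a number at least 10 percentage points lower from compound 1 to compound 3 (that floor lies within the scatter). This first change at this position therefore shows no loss that clearly exceeds the scatter, so the benzylamino group is not shown to matter here.

As far as these compounds go, whether the ring or the donor counts more stays open, and N-methylbenzylamino, which keeps the ring without the donor, would separate them. From the compounds shown here alone, whether a longer chain such as phenethylamino would raise the inhibition also stays open.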